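This account rests on a few compounds, and the source may have more. Where it says the series, first, only, none or still open, it means among the compounds named here.

Working notes on the series, step from compound 1 to compound 4.

Compound 1 `COc1ccc([C@H]2CC(C)(O)[C@@H]3CC[C@@H](C)C[C@H]3O2)cc1OC` is the reference point. In an ADME assay on MDCK cells (Canis lupus familiaris) for cytotoxicity, read by MTT assay, with a stated time of 48 h (on this read-out lower numbers stand for higher toxicity in this test and higher numbers for lower toxicity in this test), compound 1 gives > 937000 nM, which is a limit of the test and not a number. Compound 2 `COc1ccc([C@H]2CC(C)(O)[C@@H]3CC[C@@H](C)C[C@H]3O2)c(OC)c1OC` carries a methoxy in place of hydrogen on an aromatic carbon. In this assay compound 2 gives > 857000 nM, again a limit rather than a number. The step that the two limits leave unreadable from compound 1 to compound 2 is therefore not readable, as the limit of > 857000 nM in this assay, at which 1 of the 3 values shown sits, and the limit of > 937000 nM in this assay, at which 1 of the 3 values shown sits, show. Compound 3 `COc1ccc([C@H]2CC(C)(O)[C@@H]3CC[C@@H](C)C[C@H]3O2)cc1O` has hydrogen in place of methyl on an oxygen on an aromatic ring, and in this assay compound 3 gives 738000 nM. The step of an at least 1.2-fold lower number from compound 1 to compound 3 (0.10 log units; that floor lies within the scatter) is the only readable one, and its floor lies within the scatter.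

Compound 4 `COc1ccc([C@H]2CC(C)(F)[C@@H]3CC[C@@H](C)C[C@H]3O2)cc1OC` differs from compound 1 by fluoro in place of hydroxy on a saturated ring carbon. For the measured compounds named here, no measured step in this set touches the saturated ring carbon, so neither the hydroxy nor the fluoro has a precedent here. Both readable and unreadable steps stay close to or at the upper limit of this assay, so no step beyond the scatter is expected. For compound 4 the expected step is an at least 1.0-fold lower number from compound 1 to compound 4 (0.01 log units; that floor lies within the scatter). Compound 4 is estimated in this assay at 900000 nM, within 400000 nM to 2000000 nM.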

Compound 4, half-maximal cytotoxic concentration: 20000 nM
Estimate against measurement, compound 4: 45-fold (1.65 log units) above; the measured number lies below the stated range.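

Fluoro in place of hydroxy on a saturated ring carbon gives an at least 46-fold lower number from compound 1 to compound 4 (1.67 log units; beyond the scatter) in this assay, the first step in the series that lies beyond the scatter. The earlier changes, both on the aromatic ring, gave one step that cannot be read and one whose floor lies within the scatter, so this saturated ring carbon is the only place shown where a single change brings a clearly lower number, which here stands for higher toxicity in this test. The printed size is a floor and not a full measure because compound 1 stands at a limit of the test and not at a number: the limit of > 937000 nM in this assay, at which 1 of the 4 values shown sits.

From the compounds shown here alone, only compound 1 and compound 4 differ at this carbon, so it stays open whether the step follows from the hydroxy leaving or from the fluoro entering, and a hydrogen, a chloro or an amine at the same carbon would help separate the two. Also open, going by these compounds, is whether fluoro in place of hydroxy gives a step of similar size on the aromatic patterns of compound 2 and compound 3.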